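Trimming a Butyl Chain to Ethyl

This account rests on a few compounds, and the source may have more. Where it says the series, first, only, none or still open, it means among the compounds named here.

In a functional assay on Huh-7 cells (Homo sapiens) for antiproliferative activity, read by CCK-8 assay, with a stated time of 72 h (on this read-out higher numbers stand for weaker inhibition of growth and lower numbers for stronger inhibition of growth), compound 1 `CCC1C(=O)N(C)c2cnc(-n3ccc4cc(F)ccc43)nc2N1c1ccn(C)n1` is recorded as "not active" (no number reported), with no number attached. Within the data shown here, compound 2 `CCCCNC(=O)c1ccc2c(ccn2-c2ncc3c(n2)N(c2ccn(C)n2)C(CC)C(=O)N3C)c1` gives 8670 nM, the only number so far, so it cannot yet be ranked against any other measured value. Compound 3 `CCNC(=O)c1ccc2c(ccn2-c2ncc3c(n2)N(c2ccn(C)n2)C(CC)C(=O)N3C)c1` differs from compound 2 in a single place, where butyl becomes ethyl: hydrogen in place of ethyl on a saturated chain carbon, two bonds along the chain from an amide-type nitrogen. Among the measured compounds shown here, no pair of measured compounds shows what this kind of change does in this assay, so the expectation has little to rest on beyond compound 2 at 8670 nM. A small shift is expected, barely beyond the usual scatter, and leaning towards weaker inhibition of growth. The expected change, a 1.2-fold higher number from compound 2 to compound 3 (0.06 log units; within the scatter), is therefore modest and uncertain. For compound 3 the estimated value is 10000 nM, with an expected range of 4000 nM to 25000 nM.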

Compound 3, concentration for 50% growth inhibition: 20300 nM
Compound 3: middle estimate off by 2.0-fold (0.31 log units), on the low side, and the stated range covers the measured number.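

In this assay, trimming butyl to ethyl gives a 2.3-fold higher number from compound 2 to compound 3 (0.37 log units; beyond the scatter), so this chain is not a silent part of the molecule: the shorter chain goes with weaker inhibition of growth. Among these compounds, this is the first measured step at this position, and as a single pair it gives a direction for these two compounds only, not a general rule about chain length. Nothing measured here gives a reason for the shift. On these data alone, it remains open whether a longer chain such as hexyl, or a chain carrying an amine or a carboxylic acid, would strengthen inhibition of growth or weaken it further. Also open, as far as these compounds go, is whether the number would keep rising with methyl in place of ethyl, which would show if the direction seen in this one pair holds further along the series.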